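The compounds below may be only part of what the source reports. "The series", "measured", "known", "first", "only" and "open" are said of these compounds alone.

Compound 3 `COc1ccc(-c2nc3ccccc3o2)cc1NC(=O)c1cnccc1Cl` is one of three close relatives examined in an ADME assay on HEK293 cells (Homo sapiens) for inhibition, with a stated time of 72 h; on this read-out higher numbers stand for an effect only at larger amounts of compound and lower numbers for an effect already at smaller amounts. In this assay compound 3 gives only a limit of > 25000 nM. Compound 1 `COc1ccc(-c2nc3ccccc3s2)cc1NC(=O)c1cnccc1Cl` gives only a limit of > 25000 nM. Compound 2 `Cc1ccc(-c2nc3ccccc3o2)cc1NC(=O)c1cnccc1Cl` likewise gives only a limit of > 25000 nM. The steps a step that the two limits leave unreadable from compound 1 to compound 3 and a step that the two limits leave unreadable from compound 2 to compound 3 therefore carry no readable size; what the three share is the limit of > 25000 nM in this assay, at which 3 of the 3 values shown sit. Compound 4 `O=C(Nc1cc(-c2nc3ccccc3o2)ccc1F)c1cnccc1Cl` differs from compound 3 by fluoro in place of methoxy on an aromatic carbon. For the measured compounds named here, no measured step bears on this change with a readable size, so no direction can be drawn from the series. The expected step is a step that the limit leaves unreadable from compound 3 to compound 4, that is no readable movement, with a limit again the most probable outcome. For compound 4 the estimate in this assay is 30000 nM, with a range from 10000 nM to 100000 nM.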

Compound 4, half-maximal effective concentration: > 25000 nM
Compound 4: only a limit was reported (the forecaster's own chance of this, stated with the estimate: 85%); the middle value is on the limit's open side.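

Compound 4 gives only a limit of [ > 25000 nM ] in this assay, so no step from compound 2 or compound 3 to compound 4 can be read: the limit of > 25000 nM in this assay, at which 4 of the 4 values shown sit.

The compounds shown leave open whether any change to the shared core moves the read-out in this assay.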